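The source may hold more compounds than are shown below. What is called first, only, known or untested is meant among the compounds shown, and "the series" means these compounds.

Three compounds that differ only in the aromatic group on a saturated chain carbon bound to an aromatic carbon have been measured in a functional assay on P388 cells (Mus musculus) for cytotoxicity; on this read-out higher numbers stand for weaker inhibition and lower numbers for stronger inhibition. Compound 1 `Cc1cc(-c2c(F)cc3c(=O)c(Cc4cccc(O)c4)cn(C4CC4)c3c2F)cc(C)n1`, carrying 3-hydroxyphenyl, gives 2200 nM. Compound 2 `Cc1cc(-c2c(F)cc3c(=O)c(Cc4ccc(Cl)cc4)cn(C4CC4)c3c2F)cc(C)n1`, carrying 4-chlorophenyl, gives 20000 nM. Compound 3 `COc1ccc(Cc2cn(C3CC3)c3c(F)c(-c4cc(C)nc(C)c4)c(F)cc3c2=O)cc1`, carrying 4-methoxyphenyl, gives 21000 nM. Compound 3 therefore stands level with compound 2, as the comparison shows a 1.1-fold higher number from compound 2 to compound 3 (0.02 log units; within the scatter), and both are clearly weaker than compound 1.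

The next compound, compound 4 `Cc1cc(-c2c(F)cc3c(=O)c(Cc4ccccc4O)cn(C4CC4)c3c2F)cc(C)n1`, makes a single change to compound 3: 2-hydroxyphenyl in place of 4-methoxyphenyl on a saturated chain carbon bound to an aromatic carbon. In words, 2-hydroxyphenyl takes the place of 4-methoxyphenyl. The most relevant evidence is the comparison that shows a 9.5-fold higher number from compound 1 to compound 3 (0.98 log units; beyond the scatter), supported by the one that shows a 9.1-fold higher number from compound 1 to compound 2 (0.96 log units; beyond the scatter). Each time, the compound with 3-hydroxyphenyl has the lower number. However, no measured compound carries 2-hydroxyphenyl, so the data do not show whether the benefit seen with 3-hydroxyphenyl carries over in full. Only part of it is assumed here.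

The expected result is a modest move towards stronger inhibition, a 5.3-fold lower number from compound 3 to compound 4 (0.72 log units; beyond the scatter). For compound 4 the estimated value is 4000 nM, with an expected range of 1200 nM to 15000 nM.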

Compound 4, half-maximal inhibitory concentration: 670 nM
Compound 4: the middle estimate sits 6.0-fold (0.78 log units) above what was measured, outside the stated range (below it).
By their numbers in this assay, from the lowest: compound 4; then compound 1; then compounds 2 and 3 (each within the scatter of the next).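

Among the compounds shown here, the gain in this assay from this change is larger than any step among the earlier compounds: 2-hydroxyphenyl in place of 4-methoxyphenyl gives (a 31-fold lower number from compound 3 to compound 4 (1.50 log units; beyond the scatter)), and in place of 4-chlorophenyl it gives (a 30-fold lower number from compound 2 to compound 4 (1.47 log units; beyond the scatter)). For the compounds shown here, the earlier compounds held only one hydroxyphenyl group, so they could not show that two such groups give different results at this place on a saturated chain carbon bound to an aromatic carbon. Here, 2-hydroxyphenyl in place of 3-hydroxyphenyl gives (a 3.3-fold lower number from compound 1 to compound 4 (0.52 log units; beyond the scatter)), which puts compound 4 at the lowest number of the four. Nothing available here explains why these groups differ.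

Compound 4 differs from compound 3 in both the kind of group on the ring and its place, so the compounds shown do not separate these two changes, and 4-hydroxyphenyl and 2-methoxyphenyl would be the direct tests. Going by these compounds, it also remains open whether 2-aminophenyl could stand in for 2-hydroxyphenyl, and whether the low number of compound 4 would survive a longer chain carrying the same ring.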